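Shifting the hydroxyl around the aryl imine

The source may report more compounds than this note shows. Statements on the series, on what has been measured and on what is new or still open speak of the compounds shown alone.

Of the compounds shown here, three built on one shared core have been tested in an ADME assay on HEK293 cells (Homo sapiens) for cytotoxicity; on this read-out lower numbers stand for stronger inhibition and higher numbers for weaker inhibition. Compound 1 `CCCCCCCCCCCCCCNC(=O)[C@H](CO)/N=C/c1ccccc1OC` gives 79200 nM, compound 2 `CCCCCCCCCCCCCCNC(=O)[C@H](CO)/N=C/c1ccc(Cl)cc1` gives 77700 nM, and compound 3 `CCCCCCCCCCCCCCNC(=O)[C@H](CO)/N=C/c1ccccc1O` gives 80800 nM. Compound 3 carries the highest of the three numbers, yet the gaps are tiny: a 1.0-fold higher number from compound 1 to compound 3 (0.01 log units; within the scatter) and a 1.0-fold higher number from compound 2 to compound 3 (0.02 log units; within the scatter), and equally a 1.0-fold lower number from compound 1 to compound 2 (0.01 log units; within the scatter). No order among the three can be claimed; all three aryl groups behave as one.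

Compound 4 `CCCCCCCCCCCCCCNC(=O)[C@H](CO)/N=C/c1cccc(O)c1` has not yet been measured in this assay. It differs from compound 3 by 3-hydroxyphenyl in place of 2-hydroxyphenyl on a carbon with a double bond to nitrogen. Within the data shown here, no measured step exchanges one hydroxyphenyl isomer for another, so the only guidance comes from the three steps above, each of which swaps the aryl group on the carbon with a double bond to nitrogen and each of which stayed within the scatter. Since an exchange of the whole ring substituent left the number untouched, a change in where the hydroxyl sits is expected to do the same, and the step of a 1.0-fold lower number from compound 3 to compound 4 (0.00 log units; within the scatter) is expected to fall within the scatter. Compound 4 is therefore estimated at 80000 nM, with a range from 40000 nM to 160000 nM.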

Compound 4, half-maximal inhibitory concentration: 77500 nM
Estimate against measurement, compound 4: 1.0-fold (0.01 log units) above; low and high end bracket the measured number.
By their numbers in this assay, from the lowest: compounds 4, 2, 1 and 3 (each within the scatter of the next).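

In this assay, the step that exchanges one hydroxyphenyl isomer for another on the carbon with a double bond to nitrogen gives a 1.0-fold lower number from compound 3 to compound 4 (0.02 log units; within the scatter) and thus shows that where the hydroxyl sits makes no readable difference among these two isomers. The new compound also shows no separation from the other two aryl groups, with a 1.0-fold lower number from compound 2 to compound 4 (0.00 log units; within the scatter) and with a 1.0-fold lower number from compound 1 to compound 4 (0.01 log units; within the scatter) as the remaining steps, so 2-hydroxyphenyl, 3-hydroxyphenyl, 4-chlorophenyl and 2-methoxyphenyl cannot be told apart at this place, and no compound shown goes against that. Nothing available explains why these four aryl groups read alike.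

The compounds shown leave open whether an amine or a carboxylic acid on the aromatic ring would stay within the same narrow band, since only hydroxyl, methoxy and chloro substituents appear there. From the compounds shown here alone, all four compounds also share the same core with its long chain on the amide nitrogen, so it remains open whether a shorter chain, or a change elsewhere in that core, would move the number in this assay at all.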